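The source may hold more compounds than are shown below. What is called first, only, known or untested is meant among the compounds shown, and "the series" means these compounds.

In an ADME assay for permeability, using PAMPA, at pH 7.4 (a lower number here means that the compound crosses the layer more slowly, a higher number that the compound crosses the layer faster), compound 1 `CC(C)COc1ncc(-c2cn(C)c3cc(C(=O)NS(=O)(=O)C4CC4)c(F)cc23)cc1Cl` gives 310 nm/s and compound 2 `CC(C)COc1ccc(-c2cn(C)c3cc(C(=O)NS(C)(=O)=O)c(F)cc23)cn1` gives 164 nm/s in the same test. For the measured compounds named here, these two values lie within the scatter of each other, so compound 2 cannot be separated from the only other measured compound. Compound 3 `CC(C)COc1ccc(-c2cn(C)c3cc(C(=O)NS(=O)(=O)C4CC4)c(F)cc23)cn1` is still unmeasured. It differs from compound 2 by cyclopropyl in place of methyl on a sulfonyl sulfur. Going by the values given here, no measured pair shows this change on its own, so the evidence is thin. With compound 1 at 310 nm/s and also carrying cyclopropyl on a sulfonyl sulfur, a small rise in this assay is expected, one that may well stay within the scatter. The estimated change is a 1.3-fold higher number from compound 2 to compound 3 (0.13 log units; within the scatter) on this reasoning. The expected value for compound 3 is 220 nm/s with an estimated range from 110 nm/s to 430 nm/s for repeat measurements.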

Compound 3, apparent permeability: 254 nm/s
Estimate against measurement, compound 3: 1.2-fold (0.06 log units) below; low and high end bracket the measured number.
By their numbers in this assay, from the lowest: compounds 2, 3 and 1 (each within the scatter of the next).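

In this assay, cyclopropyl in place of methyl on a sulfonyl sulfur can now be read as a single change, and it amounts to a 1.5-fold higher number from compound 2 to compound 3 (0.19 log units; within the scatter) with nothing else differing. Compound 3 also isolates a second place, where hydrogen in place of chloro on an aromatic carbon amounts to a 1.2-fold lower number from compound 1 to compound 3 (0.09 log units; within the scatter) on the same cyclopropylsulfonyl background, so neither change separates its two compounds. No measurement shown here offers an explanation for either reading.

The compounds shown leave open how this assay would read with a longer chain or an amine on the sulfonyl sulfur, or with a nitrile on the aromatic carbon that carries chloro in compound 1. As far as these compounds go, each change is also seen only once, so whether its size holds on other compounds remains unknown.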